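A few compounds are considered here, and "the series" means these few. Any claim that something is new, unique, unknown or untested is made for them only; others in the source may bear on it.

Compound 1 `CC(C)NC(=O)[C@H]1CC[C@@H](n2/c(=N/C(=O)c3ccc(F)c(F)c3)[nH]c3ccc(CN4CCC(C(C)(C)O)CC4)cc32)CC1`: 60 mL.min-1.g-1
Compound 2 `CC(C)NC(=O)[C@H]1CC[C@@H](n2/c(=N/C(=O)c3ccc(F)cc3)[nH]c3ccc(CN4CCCCC4)cc32)CC1`: 302 mL.min-1.g-1
Compound 3 `CCNC(=O)[C@H]1CC[C@@H](n2/c(=N/C(=O)c3ccccc3)[nH]c3ccc(CN4CCCCC4)cc32)CC1`: 194 mL.min-1.g-1

In an in vitro ADME assay on microsomes from liver (Homo sapiens) for metabolic stability (a higher number here means faster removal of the compound, a lower number slower removal), compound 1 gives 60 mL.min-1.g-1, the lowest of the three numbers. Compound 3 gives 194 mL.min-1.g-1 and compound 2 gives 302 mL.min-1.g-1; both gaps to compound 1 lie beyond the scatter, so compound 1 is the most slowly removed of the three. Compound 4 `CC(C)NC(=O)[C@H]1CC[C@@H](n2/c(=N/C(=O)c3cccc(C#N)c3)[nH]c3ccc(CN4CCC(C(C)(C)O)CC4)cc32)CC1` has not yet been measured. It differs from compound 1 in one place: 3-cyanophenyl in place of 3,4-difluorophenyl on a carbonyl carbon. Within the data shown here, no measured pair shows this change by itself, so its direction rests on no direct precedent. A step within the usual scatter is expected, leaning if anything toward faster removal. The estimated step is a 1.3-fold higher number from compound 1 to compound 4 (0.12 log units; within the scatter). For compound 4 the expected value is 80 mL.min-1.g-1, with a range from 35 mL.min-1.g-1 to 180 mL.min-1.g-1.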

Compound 4, intrinsic clearance in microsomes: 72 mL.min-1.g-1
Estimate against measurement, compound 4: 1.1-fold (0.05 log units) above; low and high end bracket the measured number.
By their numbers in this assay, from the lowest: compounds 1 and 4 (each within the scatter of the next); then compounds 3 and 2 (each within the scatter of the next).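

In this assay, the step from 3,4-difluorophenyl to 3-cyanophenyl on a carbonyl carbon is a 1.2-fold higher number from compound 1 to compound 4 (0.08 log units; within the scatter), the first single change seen at this position. Here, the nitrile-bearing ring and the difluorinated ring cannot be told apart, so this position accepted this exchange without a readable change in removal. Nothing at hand explains this result. Still open, as far as these compounds go, is whether a carboxylic acid or an amine on a carbonyl carbon in place of 3,4-difluorophenyl would leave the number equally undisturbed.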